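Trimming the Acyl Group: Permeability Expectation for Compound 4

The compounds below may be only part of what the source reports. "The series", "measured", "known", "first", "only" and "open" are said of these compounds alone.

Compound 1, `Cn1cncc1CN1CC(N(CC2CCN(C(=O)c3ccc(Cl)cc3)CC2)S(=O)(=O)c2ccccn2)Cc2cc(C#N)ccc21`, gives 0.5 10^-6 cm/s in an ADME assay on Caco-2 cells (Homo sapiens) for permeability, in the apical to basolateral direction; on this read-out higher numbers stand for higher permeability and lower numbers for lower permeability.
Compound 2, `Cn1cnc(S(=O)(=O)N2CCC(CN(C3Cc4cc(C#N)ccc4N(Cc4cncn4C)C3)S(=O)(=O)c3ccccn3)CC2)c1`, gives 0.1 10^-6 cm/s.
Compound 3, `Cn1cncc1CN1CC(N(CC2CCN(C(=O)C(C)(C)C)CC2)S(=O)(=O)c2ccccn2)Cc2cc(C#N)ccc21`, gives 0.5 10^-6 cm/s.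

Compound 3 stands level with compound 1 at the digits shown, and the two together are the highest of the three numbers; compound 2 sits furthest off, a 5.0-fold higher number from compound 2 to compound 3 (0.70 log units; beyond the scatter). Compound 4, `CC(=O)N1CCC(CN(C2Cc3cc(C#N)ccc3N(Cc3cncn3C)C2)S(=O)(=O)c2ccccn2)CC1`, differs from compound 3 in one place: methyl in place of tert-butyl on a carbonyl carbon. Within the data shown here, the one measured step touching the same carbonyl carbon, no change at the digits printed from compound 1 to compound 3 (within the scatter), left this assay unchanged. The step that did move the number, a 5.0-fold lower number from compound 1 to compound 2 (0.70 log units; beyond the scatter), lies at another position. Only a small step, within the scatter, is therefore expected: a 1.3-fold lower number from compound 3 to compound 4 (0.10 log units; within the scatter). Compound 4 is expected to give about 0.4 10^-6 cm/s, between 0.15 10^-6 cm/s and 1 10^-6 cm/s.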

Compound 4, apparent permeability: 0.5 10^-6 cm/s
Compound 4: the middle estimate sits 1.3-fold (0.10 log units) below what was measured; low and high end bracket the measured number.
By their numbers in this assay, from the lowest: compound 2; then compounds 1, 3 and 4 (each within the scatter of the next).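

On the carbonyl carbon, this assay now gives no change at the digits printed from compound 3 to compound 4 (within the scatter) and no change at the digits printed from compound 1 to compound 4 (within the scatter), so methyl, tert-butyl and 4-chlorophenyl all read alike there. Even a single carbon on the carbonyl keeps compound 4 apart from the sulfonyl compound, with a 5.0-fold higher number from compound 2 to compound 4 (0.70 log units; beyond the scatter). Nothing available explains why this position gives the same reading with all three groups.

Going by these compounds, whether an amine or a carboxylic acid on this carbonyl carbon would also leave the number unmoved remains open. So does whether a simple methylsulfonyl group would match the low number of compound 2.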